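Solubility Outlook for a Fluoro-Methylpyridyl Ether Analogue

The source may hold more compounds than are shown below. What is called first, only, known or untested is meant among the compounds shown, and "the series" means these compounds.

Measured so far:
- compound 1 `Cn1c(COc2cccc(C(=O)O)c2)nc2ccc(Oc3ccc(F)cc3)nc21` gives 11 ug/mL
- compound 2 `Cn1c(COc2cccc(C(=O)O)c2)nc2ccc(Oc3cccc(Cl)n3)cc21` gives 7.7 ug/mL

Both compounds share a core and were tested in a physicochemical assay for solubility, read by HPLC, measured as thermodynamic solubility, with a stated time of 4 h, at pH 6.8; a lower number here means a less soluble compound, a higher number a more soluble compound. Compound 2 holds the lowest of the two numbers, and its nearest neighbour is compound 1, whose number is higher by an amount that falls within the usual scatter of this assay, so the two readings cannot be told apart with confidence. Among the measured compounds shown here, no pair of these measured compounds differs in only one place, so no single-change step is available from them.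

The next compound, compound 3 `Cc1cc(F)cnc1Oc1ccc2nc(COc3cccc(C(=O)O)c3)n(C)c2c1`, has not yet been measured. It differs from compound 2 in one place: 5-fluoro-3-methylpyridin-2-yl in place of 6-chloropyridin-2-yl on an oxygen on an aromatic ring. The leaving and entering groups are of similar size and carry the same count of hydrogen-bond donors and acceptors. For the measured compounds named here, with no measured step to lean on, the expected step of a 1.1-fold lower number from compound 2 to compound 3 (0.04 log units; within the scatter) is small, with no direction beyond the scatter. Compound 3 is estimated at 7 ug/mL, with a likely range from 2.5 ug/mL to 20 ug/mL.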

Compound 3, solubility: 14 ug/mL
Estimate against measurement, compound 3: 2.0-fold (0.30 log units) below; the measured number falls inside the stated range.
By their numbers in this assay, from the lowest: compounds 2, 1 and 3 (each within the scatter of the next).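

In this assay, among the compounds shown here, the swap of 6-chloropyridin-2-yl for 5-fluoro-3-methylpyridin-2-yl on an oxygen on an aromatic ring provides the first single-change step in this set (a 1.8-fold higher number from compound 2 to compound 3 (0.26 log units; within the scatter)), and the two readings cannot be told apart with confidence. At this place, then, two differently substituted pyridine groups with the same hydrogen-bond donor and acceptor counts, one with 7 heavy atoms and the other with 8, gave no readable difference, although this rests on a single pair of compounds. No measured evidence is available here to explain the result, and with a step this small there is no real difference to explain.

The fluorine and the methyl group enter together while the chlorine leaves, so this step cannot separate what each of these alterations contributes on its own, or show whether any one of them matters. Going by these compounds, it also remains open whether a group of a different kind at this place, such as a pyridine ring carrying an amine or a morpholine, would give a step beyond the scatter.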